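The source may report more compounds than this note shows. Statements on the series, on what has been measured and on what is new or still open speak of the compounds shown alone.

In a functional assay on HUVEC cells (Homo sapiens), read by BrdU incorporation, with a stated time of 72 h (a lower number here means a stronger inhibitor, a higher number a weaker inhibitor), compound 1 `Cc1ccc2nc(Cl)c(/C=C/C(=O)c3sccc3C)cc2c1` gives 127 nM, compound 2 `Cc1ccc2nc(Cl)c(/C=C/C(=O)c3ccc(Cl)s3)cc2c1` gives 59.4 nM and compound 3 `Cc1ccc2nc(Cl)c(/C=C/C(=O)c3ccc(Br)s3)cc2c1` gives 88.4 nM. Compound 3 stands within the scatter of both other compounds: a 1.4-fold lower number from compound 1 to compound 3 (0.16 log units; within the scatter) and a 1.5-fold higher number from compound 2 to compound 3 (0.17 log units; within the scatter). Only a 2.1-fold lower number from compound 1 to compound 2 (0.33 log units; beyond the scatter) passes beyond the scatter, and that step is modest.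

The next change again falls on the carbonyl carbon. Compound 4 `Cc1csc(C(=O)/C=C/c2cc3cc(C)ccc3nc2Cl)c1` carries 4-methylthiophen-2-yl in place of 5-bromothiophen-2-yl (4-methylthiophen-2-yl in place of 5-bromothiophen-2-yl on a carbonyl carbon). Within the data shown here, no measured compound carries this group, so the effect of moving the methyl is untested. The nearest comparison is compound 1, which also bears a methyl-substituted group and reads 127 nM. The two steps that reach compound 3 both stay within the scatter, so neither supports a large shift. A step no larger than the scatter is therefore expected in this assay, with a slight lean towards a higher number, in line with compound 1. The expected step is a 1.2-fold higher number from compound 3 to compound 4 (0.09 log units; within the scatter). For compound 4 the estimated value is 110 nM, with an expected range of 50 nM to 240 nM.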

Compound 4, half-maximal inhibitory concentration: 106 nM
For compound 4 the middle estimate is 1.0-fold (0.02 log units) above the measured one, within the range that was stated.
By their numbers in this assay, from the lowest: compounds 2, 3, 4 and 1 (each within the scatter of the next, the first and the last beyond it).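

In this assay, 4-methylthiophen-2-yl on the carbonyl carbon stays within the scatter of all three groups seen before it (a 1.2-fold higher number from compound 3 to compound 4 (0.08 log units; within the scatter); a 1.8-fold higher number from compound 2 to compound 4 (0.25 log units; within the scatter); a 1.2-fold lower number from compound 1 to compound 4 (0.08 log units; within the scatter)). This position therefore tolerates a methyl-bearing thiophene as well as a halogen-bearing one, at least at the resolution of this assay: the 4-methyl and 3-methyl groups cannot be told apart, and neither can the 4-methyl group and either halogen-bearing group. Among these compounds, the earlier compounds offered only one comparison beyond the scatter (a 2.1-fold lower number from compound 1 to compound 2 (0.33 log units; beyond the scatter)), and compound 4 does not extend it into a methyl-against-halogen trend, since its step to compound 2 stays within the scatter; no measurement is available here that would explain these numbers.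

All four compounds keep a substituted thiophen-2-yl on the carbonyl carbon, so the tolerance of this position is known only for methyl, chloro and bromo. Open, from the compounds shown here alone, is whether an amine or a carboxylic acid on that thiophene, or a longer chain such as ethyl in place of the methyl, would move the number beyond the scatter of these four compounds.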